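The source may hold more compounds than are shown below. What is called first, only, known or untested is meant among the compounds shown, and "the series" means these compounds.

Compound 1 `O=C1O[C@H]([C@@H](O)Cn2cc(CNS(=O)(=O)c3ccc(F)cc3)nn2)C(OCc2ccccc2)=C1OCc1ccccc1` gives 41100 nM in a functional assay on SW-620 cells (Homo sapiens) for antiproliferative activity, read by MTT assay, with a stated time of 72 h; a higher number here means a weaker inhibitor, a lower number a stronger inhibitor. Compound 2 `CCCCCCCCCCc1cn(C[C@H](O)[C@H]2OC(=O)C(OCc3ccccc3)=C2OCc2ccccc2)nn1` gives 45200 nM in this assay. Compound 3 `O=C1O[C@H]([C@@H](O)Cn2cc(C3CC3)nn2)C(OCc2ccccc2)=C1OCc1ccccc1` gives 54200 nM in this assay.

On these numbers compound 3 cannot be set apart from its two companions: the step of a 1.2-fold higher number from compound 2 to compound 3 (0.08 log units; within the scatter) and the step of a 1.3-fold higher number from compound 1 to compound 3 (0.12 log units; within the scatter) both lie within the scatter, as does the step of a 1.1-fold higher number from compound 1 to compound 2 (0.04 log units; within the scatter). The three measured compounds share one core and differ only in the group carried on the same aromatic carbon of the five-membered ring, and none of those swaps moved the number beyond the scatter.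

Compound 4 `COc1ccc(-c2cn(C[C@H](O)[C@H]3OC(=O)C(OCc4ccccc4)=C3OCc3ccccc3)nn2)cc1` continues that series: 4-methoxyphenyl in place of cyclopropyl on an aromatic carbon. Going by the values given here, the three measured steps are the only evidence that bears on this change, and each of them exchanged one substituent at this position for a very different one without any effect beyond the scatter. Among the compounds with values here, the new group is larger than cyclopropyl and is aromatic, but nothing among the measured compounds points to a direction. The expectation is therefore a step of a 1.1-fold lower number from compound 3 to compound 4 (0.04 log units; within the scatter), that is, no change beyond the scatter. Compound 4 is expected to give about 50000 nM in this assay, within the range 20000 nM to 125000 nM.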

Compound 4, half-maximal inhibitory concentration: 58200 nM
Estimate against measurement, compound 4: 1.2-fold (0.07 log units) below; the range from low to high includes it.
By their numbers in this assay, from the lowest: compounds 1, 2, 3 and 4 (each within the scatter of the next).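

Putting 4-methoxyphenyl in place of cyclopropyl on this aromatic carbon of the five-membered ring adds a six-membered aromatic ring and a hydrogen-bond acceptor, yet in this assay it gives a 1.1-fold higher number from compound 3 to compound 4 (0.03 log units; within the scatter). The comparisons with the decyl group and with the (((4-fluorophenyl)sulfonyl)amino)methyl group read the same way, at a 1.3-fold higher number from compound 2 to compound 4 (0.11 log units; within the scatter) and a 1.4-fold higher number from compound 1 to compound 4 (0.15 log units; within the scatter), so an aromatic ring attached directly to this carbon now joins a small ring, a long chain and a sulfonamide-bearing group, and none of the four sets itself apart from the others in this assay. No measurement among those available offers an explanation for this flat result.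

The compounds shown leave open whether any group on this carbon can move the number beyond the scatter, for example a carboxylic acid, a primary amine or a 4-hydroxyphenyl ring. They also leave open whether changes elsewhere on the shared core would matter more, such as a free hydroxyl in place of either benzyloxy group, since both benzyloxy groups stay the same in all four compounds.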